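This account rests on a few compounds, and the source may have more. Where it says the series, first, only, none or still open, it means among the compounds named here.

The measured compounds:
Compound 1, `CC(C)=CC[C@@H](OC(=O)CCO)C1=CC(=O)c2c(O)ccc(O)c2C1=O`: in a functional assay on DU-145 cells (Homo sapiens) for cytotoxicity, read by MTT assay (a lower number here means a stronger inhibitor, a higher number a weaker inhibitor), compound 1 gives 55300 nM.
Compound 2, `CC(C)=CC[C@@H](OC[C@@H](C)O)C1=CC(=O)c2c(O)ccc(O)c2C1=O`: compound 2 gives 14300 nM.
Compound 3, `CCCCCCC(C)(O)CC(=O)O[C@H](CC=C(C)C)C1=CC(=O)c2c(O)ccc(O)c2C1=O`: for compound 3 only a limit of the assay is known, > 100000 nM.

Compound 3 thus stands apart from the other two in that its result is a limit, not a number. Compound 4, `CCCCC(C)(O)CC(=O)O[C@H](CC=C(C)C)C1=CC(=O)c2c(O)ccc(O)c2C1=O`, differs from compound 3 in one place: hydrogen in place of ethyl on a saturated chain carbon, five bonds along the chain from an oxygen on a saturated carbon. Of the measured steps, the one that bears on this is the lengthening of the same chain, which gave an at least 1.8-fold higher number from compound 1 to compound 3 (0.25 log units; that floor lies within the scatter); the other, a 3.9-fold lower number from compound 1 to compound 2 (0.59 log units; beyond the scatter), altered a different part of the molecule and says little here. Trimming the chain part of the way back toward compound 1 might be expected, if anything, to lower the number slightly, but since the measured step in the opposite direction stayed within the scatter, no step beyond the scatter is expected, and the result may again be a limit. Compound 4 is therefore expected to give about 90000 nM, between 35000 nM and 250000 nM. The change from compound 3 to compound 4 that this estimate means is expected to be an at least 1.1-fold lower number from compound 3 to compound 4 (0.04 log units; that floor lies within the scatter).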

Compound 4, half-maximal inhibitory concentration: 76500 nM
Compound 4: middle estimate off by 1.2-fold (0.07 log units), on the high side, within the range that was stated.
By their numbers in this assay, from the lowest: compound 2; then compounds 1 and 4 (each within the scatter of the next). At a limit, above all of these: compound 3.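

In this assay compound 3 stands at a limit, not a number: the limit of > 100000 nM in this assay, at which 1 of the 4 values shown sits.

Going by these compounds, replacing ethyl with hydrogen at this place on the chain gives an at least 1.3-fold lower number from compound 3 to compound 4 (0.11 log units; that floor lies within the scatter), so this step is only a floor and the true size of the change remains unknown. What compound 4 adds is a real number for an ester with a long branched chain, and that number shows two things: the longer chain makes no difference beyond the scatter against the short ester, with a 1.4-fold higher number from compound 1 to compound 4 (0.14 log units; within the scatter), whereas the change of the whole side group gives a 5.3-fold higher number from compound 2 to compound 4 (0.73 log units; beyond the scatter).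

On these data alone, it remains open whether a still shorter chain, such as one ending in propyl, would move the number beyond the scatter. As far as these compounds go, it is also open how an amine or a carboxylic acid at the end of this chain would read.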